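The source may report more compounds than this note shows. Statements on the series, on what has been measured and on what is new or still open speak of the compounds shown alone.

In an in vitro ADME assay on microsomes from liver (Homo sapiens) for pharmacokinetics, read by LC-MS, with a stated time of 10 min, tested at 1 uM (on this read-out lower numbers stand for slow clearance and higher numbers for fast clearance), compound 1 (`Cc1cccc(NC(=O)[C@H]2CN(C)C[C@@H]2c2ccc(/C=C/C(=O)Nc3ccccc3N)cc2)c1`) gives 14 mL/min/kg and compound 2 (`CN1C[C@H](C(=O)Nc2ccc(F)cc2F)[C@@H](c2ccc(/C=C/C(=O)Nc3ccccc3N)cc2)C1`) gives 12 mL/min/kg on the same read-out. Compound 3 (`CC(C)(CO)N1C[C@H](C(=O)Nc2ccc(Cl)cc2)[C@@H](c2ccc(/C=C/C(=O)Nc3ccccc3N)cc2)C1`) gives 12 mL/min/kg and stands level with compound 2 at the digits shown, with compound 1 within the scatter of both.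

Compound 4 (`Nc1ccccc1NC(=O)/C=C/c1ccc([C@H]2CN(C3CCOCC3)C[C@@H]2C(=O)Nc2ccc(Cl)cc2)cc1`) is not yet measured. It carries oxan-4-yl in place of 1-(hydroxymethyl)-1-methylethyl on an amine nitrogen in a ring.

Within the data shown here, the only measured step that changes one place is a 1.2-fold lower number from compound 1 to compound 2 (0.07 log units; within the scatter) and it stays within the scatter. That step concerns 2,4-difluorophenyl in place of 3-methylphenyl on an amide-type nitrogen, so it bears on the new exchange only indirectly. Among the measured compounds shown here, no measured step changes the group on the amine nitrogen alone. Compound 3 differs from compound 2 in more than one place, yet their values are level.

On this thin basis, no step beyond the scatter is expected in this assay and no direction can be favoured. The estimated change is a 1.1-fold higher number from compound 3 to compound 4 (0.03 log units; within the scatter) and it is expected to remain within the scatter. For compound 4 the estimated clearance is 13 mL/min/kg with an expected range from 8 mL/min/kg to 22 mL/min/kg on this read-out.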

Compound 4, clearance: 12 mL/min/kg
Estimate against measurement, compound 4: 1.1-fold (0.03 log units) above; the measured number falls inside the stated range.
By their numbers in this assay, from the lowest: compounds 2, 3, 4 and 1 (each within the scatter of the next).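

In this assay the group on the amine nitrogen in a ring now has its first single-place step, no change at the digits printed from compound 3 to compound 4 (within the scatter), with the (4-chlorophenyl)carbamoyl group and the rest of the core unchanged. This step replaces 1-(hydroxymethyl)-1-methylethyl, which has no ring and 1 hydrogen-bond donor, with oxan-4-yl, which has one six-membered non-aromatic ring with 1 hetero atom and 0 hydrogen-bond donors. Among these compounds, for this pair, then, clearance in human liver microsomes does not distinguish the open-chain group with its donor from the ring without one, and the earlier compounds, none of which isolated this position, could not show that.

Still open, from the compounds shown here alone, is whether this position tolerates groups of another kind, such as a carboxylic acid, a basic amine carried on a longer chain or a fluorinated alkyl chain, or whether the same exchange stays as flat when the 4-chlorophenyl on the amide is replaced by another aryl group. Nothing available explains why this exchange leaves the read-out unmoved.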